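Fluoro for hydroxy on the aromatic ring of compound 2

The compounds below may be only part of what the source reports. "The series", "measured", "known", "first", "only" and "open" are said of these compounds alone.

Compound 1 `CC[C@]1(c2ccccc2Cl)OC[C@H]([C@@H]2CCCCN2)O1` and compound 2 `CC[C@]1(c2ccccc2O)OC[C@H]([C@@H]2CCCCN2)O1` share one core and differ only at a single aromatic carbon. In a functional assay (brain) for displacement of a labelled ligand, with Rattus norvegicus as the target (on this read-out lower numbers stand for stronger inhibition and higher numbers for weaker inhibition), compound 1 gives 14.3 nM, while compound 2 gives 293 nM. Going by the values given here, the one step between them, a 20-fold higher number from compound 1 to compound 2 (1.31 log units; beyond the scatter), accounts for all that is known: compound 2 therefore stands at the highest of the two numbers measured in this assay, with compound 1 as its only neighbour.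

Compound 3 `CC[C@]1(c2ccccc2F)OC[C@H]([C@@H]2CCCCN2)O1` is the next member of the series and awaits its measurement in this assay. It differs from compound 2 by fluoro in place of hydroxy on an aromatic carbon. Among the compounds with values here, the only measured step that bears on this change is the one from chloro to hydroxy, which was large and ran toward weaker inhibition; the new group is, like chloro, a single halogen atom without a hydrogen-bond donor or acceptor. On that basis a large step back toward the number of compound 1 is expected, and compound 3 is estimated at 30 nM, in a range from 8 nM to 120 nM, an expected step of a 9.8-fold lower number from compound 2 to compound 3 (0.99 log units; beyond the scatter).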

Compound 3, inhibition constant: 36 nM
Compound 3: middle estimate off by 1.2-fold (0.08 log units), on the low side; the range from low to high includes it.
By their numbers in this assay, from the lowest: compound 1; then compound 3; then compound 2.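

In this assay, fluoro in place of hydroxy gives an 8.1-fold lower number from compound 2 to compound 3 (0.91 log units; beyond the scatter), so a second halogen on this aromatic carbon, ortho to a large group, recovers most of the ground lost with hydroxy. The two halogens are still not interchangeable here: fluoro in place of chloro gives a 2.5-fold higher number from compound 1 to compound 3 (0.40 log units; beyond the scatter), a modest step but one that lies beyond the scatter, and from the lowest number to the highest the three groups now run chloro, fluoro, hydroxy. Nothing at hand explains why the groups rank in this order.

As far as these compounds go, whether a methyl or a methoxy group, or a bromine atom, on the same aromatic carbon would stand nearer to compound 1 or to compound 2 remains open. Also open, from the compounds shown here alone, is whether the order of chloro, fluoro and hydroxy would hold on any other core, as all three compounds carry the same one.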